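A few compounds are considered here, and "the series" means these few. Any claim that something is new, unique, unknown or untested is made for them only; others in the source may bear on it.

Compound 1, `C=CCC1COC2(C=CC(=O)C=C2)N(C(C)C)C1=O`. In an assay on isolated protein for inhibition of N-lysine methyltransferase SMYD2 (Homo sapiens), read by filter binding, with a stated time of 1 h (a higher number here means a weaker inhibitor, a lower number a stronger inhibitor), compound 1 gives > 20000 nM, a limit of the assay rather than a number.
Compound 2, `CC(C)N1C(=O)C(Cc2ccc(F)cc2)COC12C=CC(=O)C=C2`. In this assay compound 2 gives > 20000 nM, again a limit of the assay.
Compound 3, `CC(C)N1C(=O)C(Cc2ccc(C#N)cc2)COC12C=CC(=O)C=C2`. In this assay compound 3 gives > 20000 nM, also a limit of the assay.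

Compound 3 therefore stands where every measured compound stands: at the limit of > 20000 nM in this assay, at which 3 of the 3 values shown sit. The steps a step that the two limits leave unreadable from compound 1 to compound 2 and a step that the two limits leave unreadable from compound 1 to compound 3 exchange the vinyl group for a substituted phenyl ring, and the step that the two limits leave unreadable from compound 2 to compound 3 swaps one substituent on that ring for another; none of them can be sized, since both ends of each sit at the limit.

Compound 4, `CC(C)N1C(=O)C(Cc2cccc(Br)c2)COC12C=CC(=O)C=C2`, differs from compound 3 by 3-bromophenyl in place of 4-cyanophenyl on a saturated chain carbon bound to a saturated ring carbon. All three measured steps bear on this kind of change, yet all are unreadable, so they give no direction. The step from compound 3 to compound 4 is estimated as a step that the limit leaves unreadable from compound 3 to compound 4, expected to stay within the scatter of what the data allow. On that basis compound 4 is expected to give about 30000 nM in this assay, with a range from 8000 nM to 100000 nM, most likely reported only as a limit.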

Compound 4, half-maximal inhibitory concentration: > 20000 nM
Compound 4 was reported as a limit (the forecaster's own chance of this, stated with the estimate: 85%); the middle value does not contradict the limit.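

Compound 4 also gives only a limit of the assay, as do compound 1, compound 2 and compound 3, so none of the steps leading to compound 4 can be read. In this assay the compounds shown leave open which change to the shared core, if any, would give a measured number rather than a limit.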